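The source may hold more compounds than are shown below. What is called first, only, known or untested is meant among the compounds shown, and "the series" means these compounds.

The series shares one core, carried by compound 2 `Cc1nc(-c2ccc(C(F)(F)F)cc2)sc1CNc1ccc(C(C)CC(=O)O)cc1`, and its potency was read in a functional assay on CHO cells for agonist activity at Free fatty acid receptor 1 (Homo sapiens); a lower number here means that less compound is needed, a higher number that more compound is needed for the effect. Within the data shown here, compound 2 gives 58.9 nM in this assay, which is the one numerical value among the two results obtained. Compound 1 `Cc1nc(-c2ccc(C(F)(F)F)cc2)sc1CNc1ccc(CCCC(=O)O)cc1` returns only a limit of the assay, < 10000 nM in this assay. The step that the limit leaves unreadable from compound 1 to compound 2 therefore cannot be sized, since the result for compound 1 is a limit (the limit of < 10000 nM in this assay, at which 1 of the 2 values shown sits). Compound 3 `Cc1nc(-c2ccc(C(F)(F)F)cc2)sc1CNc1ccc([C@H]2C[C@@H]2C(=O)NO)cc1` is not yet measured; it differs from compound 2 by 2-(hydroxycarbamoyl)cyclopropyl in place of 1-(carboxymethyl)ethyl on an aromatic carbon. Among the measured compounds shown here, no measured step reaches into this change: the one comparison available is unreadable, and neither measured compound carries a hydroxycarbamoyl group or a three-membered ring. The expectation for compound 3 in this assay rests only on compound 2, with 58.9 nM, as its nearest point. A drop in potency, an 8.5-fold higher number from compound 2 to compound 3 (0.93 log units; beyond the scatter), is estimated for the move from the acid to the hydroxamic acid on the cyclopropyl. Compound 3 is expected to give about 500 nM in this assay, within a range from 100 nM to 3000 nM.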

Compound 3, half-maximal effective concentration: 6.92 nM
Estimate against measurement, compound 3: 72-fold (1.86 log units) above; measured number below the stated range.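

In this assay, the aromatic carbon para to a large group proves open to more than the two acid side chains had shown: 2-(hydroxycarbamoyl)cyclopropyl in place of 1-(carboxymethyl)ethyl gives an 8.5-fold lower number from compound 2 to compound 3 (0.93 log units; beyond the scatter). On this shared core, then, a carboxylic acid is not required for activity at this position, and a side chain holding a three-membered ring and two defined stereocentres is compatible with a lower number than the open chain of compound 2. The steps from compound 1 to the other two compounds cannot be read, because its result is a limit and not a number: the limit of < 10000 nM in this assay, at which 1 of the 3 values shown sits.

The step to compound 3 changes the ring and the hydroxycarbamoyl group together, so the compounds shown do not separate what each contributes to the lower number. Going by these compounds, it remains open what a carboxylic acid on the same three-membered ring would give, what a hydroxycarbamoyl group on the open chain of compound 2 would give, and how the other stereoisomers of compound 3 would compare.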